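A Methoxy Group Added to the Phenyl of Compound 3

A few compounds are considered here, and "the series" means these few. Any claim that something is new, unique, unknown or untested is made for them only; others in the source may bear on it.

Three compounds sharing one core differ only in the alkyl chain on the amide nitrogen. In a functional assay on U-87MG ATCC cells for antiproliferative activity against U-87 MG (Homo sapiens), read by MTT assay, with a stated time of 72 h (on this read-out higher numbers stand for weaker inhibition and lower numbers for stronger inhibition), compound 1 `CNC(=O)c1cc(Oc2ccc(NC(=O)c3cc4cccnc4n(-c4ccccc4)c3=O)cc2)ccn1` gives 1820 nM, compound 2 `CCNC(=O)c1cc(Oc2ccc(NC(=O)c3cc4cccnc4n(-c4ccccc4)c3=O)cc2)ccn1` gives 2650 nM, and compound 3 `CCCNC(=O)c1cc(Oc2ccc(NC(=O)c3cc4cccnc4n(-c4ccccc4)c3=O)cc2)ccn1` gives 1510 nM. The steps are small: a 1.5-fold higher number from compound 1 to compound 2 (0.16 log units; within the scatter), a 1.2-fold lower number from compound 1 to compound 3 (0.08 log units; within the scatter) and a 1.8-fold lower number from compound 2 to compound 3 (0.24 log units; within the scatter). Compound 3 shows the lowest of the three numbers, but each of its gaps to the others sits within the scatter, so no ordering can be read from them.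

Compound 4 `CCCNC(=O)c1cc(Oc2ccc(NC(=O)c3cc4cccnc4n(-c4ccc(OC)cc4)c3=O)cc2)ccn1` differs from compound 3 in a different place: methoxy in place of hydrogen on an aromatic carbon. Going by the values given here, none of the measured steps touches the phenyl ring; all three concern the chain on the amide nitrogen, and all three stayed within the scatter. Among the compounds with values here, there is thus no measured step that bears on this change, and nothing in the numbers points in either direction.

The estimate for compound 4 therefore rests on compound 3 alone and is expected to be 1500 nM in this assay, with a range from 500 nM to 4500 nM. The expected step is a 1.0-fold lower number from compound 3 to compound 4 (0.00 log units; within the scatter), a step of no particular direction beyond the scatter.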

Compound 4, half-maximal inhibitory concentration: 8210 nM
Beside the measured number, compound 4's estimate is 5.5-fold (0.74 log units) below it, and the stated range ends below it.
By their numbers in this assay, from the lowest: compounds 3, 1 and 2 (each within the scatter of the next); then compound 4.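

Going by these compounds alone, the change from phenyl to 4-methoxyphenyl is the only step in this set that passes the scatter: in this assay it gives a 5.4-fold higher number from compound 3 to compound 4 (0.74 log units; beyond the scatter) and moves the number toward weaker inhibition, whereas every step in the chain on the amide nitrogen among compound 1, compound 2 and compound 3 stayed within the scatter. Among these compounds, then, a change on this aromatic carbon, para to a large group, shifts the read-out in a way that the changes to the chain did not. No measurement here accounts for the shift, so the result stands without an explanation.

With a single substituent at a single carbon, the compounds shown cannot tell whether this step belongs to methoxy in particular or would also follow from a hydroxy group, a fluorine or a methyl on the same carbon. Going by these compounds, it also remains open whether methoxy on another carbon of that ring would give a similar step, and whether the same change would carry over to the chains of compound 1 and compound 2.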